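This account rests on a few compounds, and the source may have more. Where it says the series, first, only, none or still open, it means among the compounds named here.

Compound 3 `CSc1nnc(COc2ccccc2C2=NOC(c3ccc(Cl)cc3Cl)C2)n1NC(C)=O` gives the lowest of the three numbers measured in an ADME assay (MDM cells, Homo sapiens) for cytotoxicity, read by resazurin assay, with a stated time of 3 days; a higher number here means a weaker inhibitor, a lower number a stronger inhibitor; compound 3 gives 2.7 ug/mL. Its nearest neighbour is compound 2 `CCSc1nnc(COc2ccccc2C2=NOC(c3ccc(Cl)cc3Cl)C2)n1NC(C)=O`, for which compound 2 gives 9.7 ug/mL, and the furthest is compound 1 `CCCSc1nnc(COc2ccccc2C2=NOC(c3ccc(Cl)cc3Cl)C2)n1NC(=O)CCl`, for which compound 1 gives 28.7 ug/mL.

Compound 4 `CCCSc1nnc(COc2ccccc2C2=NOC(c3ccc(Cl)cc3Cl)C2)n1NC(C)=O` has not yet been measured in this assay. It differs from compound 3 in one place: ethyl in place of hydrogen on a saturated chain carbon bound to a sulfur.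

Going by the values given here, one measured step bears directly on this change, in the opposite direction: a 3.6-fold lower number from compound 2 to compound 3 (0.56 log units; beyond the scatter). Read forward from compound 3, that step suggests that adding carbon to the chain on the sulfur raises the number. Compound 1, which carries the propylsulfanyl group of compound 4 but also a different acyl group, sits furthest from compound 3; the pair of compound 1 and compound 4 is not a single-change step, so the values of compound 1 and compound 3 are only a hint of how far the chain may push the number.

On this basis compound 4 is expected to give a modestly higher number than compound 3, a 5.9-fold higher number from compound 3 to compound 4 (0.77 log units; beyond the scatter), with the estimate for compound 4 in this assay being 16 ug/mL, in a range from 6 ug/mL to 40 ug/mL.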

Compound 4, half-maximal inhibitory concentration: 128 ug/mL
The estimate for compound 4 lay 8.0-fold (0.90 log units) below the measured number, outside the stated range (above it).
By their numbers in this assay, from the lowest: compound 3; then compound 2; then compound 1; then compound 4.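

In this assay, going by these compounds alone, the chain on the sulfur counts for much more than the earlier compounds suggested: going from methylsulfanyl to propylsulfanyl gives a 47-fold higher number from compound 3 to compound 4 (1.68 log units; beyond the scatter), and the final methyl in place of hydrogen alone gives a 13-fold higher number from compound 2 to compound 4 (1.12 log units; beyond the scatter). That single addition is classed as large, whereas the change that separates the ethylsulfanyl and methylsulfanyl compounds, a 3.6-fold lower number from compound 2 to compound 3 (0.56 log units; beyond the scatter), is classed as modest, so the number rises unevenly along the series of compound 3, compound 2 and compound 4. The result also reveals an effect at a second position, since hydrogen in place of chloro on a saturated chain carbon bound to a carbonyl carbon gives a 4.5-fold higher number from compound 1 to compound 4 (0.65 log units; beyond the scatter), which means that the value of compound 1 had hidden part of the rise that goes with the propylsulfanyl chain.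

The compounds shown offer no measured explanation for the size of this rise. They also leave open whether a longer chain such as butyl on the sulfur would raise the number further, whether an amine at the end of the chain would keep the rise, and whether the chloro step would be of similar size on the methylsulfanyl compound.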